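Side-chain exchange: ester tail to thiazolylsulfanyl tail

The compounds below may be only part of what the source reports. "The series", "measured", "known", "first", "only" and "open" are said of these compounds alone.

Compound 2 `CCOC(=O)CCCn1nc(-c2cccnc2)c2ccccc2c1=O` gives 95% in an assay on isolated protein (Oryctolagus cuniculus) with Thromboxane-A synthase (Homo sapiens) as the target, tested at 1 uM; a lower number here means less inhibition, a higher number more inhibition at the concentration tested (going by the name of the read-out). Among the measured compounds shown here, compound 1 `CC(C)=CCn1nc(-c2cccnc2)c2ccccc2c1=O` gives 94% in this assay, so the two values lie within the scatter of each other, the only measured step being a number 1 percentage points higher from compound 1 to compound 2 (within the scatter). Compound 3 `O=c1c2ccccc2c(-c2cccnc2)nn1CCSc1nccs1` carries (1,3-thiazol-2-yl)sulfanyl in place of (ethoxycarbonyl)methyl on a saturated chain carbon, two bonds along the chain from an aromatic nitrogen. For the measured compounds named here, that measured step touches the same chain and stayed within the scatter, and no other step bears on the change, so for compound 3 no movement beyond the scatter is expected in this assay, a number 2 percentage points lower from compound 2 to compound 3 (within the scatter). Compound 3 is therefore estimated at 93%, between 82% and 99%.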

Compound 3, a percentage reported as inhibition, at one concentration (the size of the read-out at that concentration, not a potency): 97%
Compound 3: the middle estimate sits 4 percentage points below what was measured, and the stated range covers the measured number.
By their numbers in this assay, from the lowest: compounds 1, 2 and 3 (each within the scatter of the next).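

Exchanging (ethoxycarbonyl)methyl for (1,3-thiazol-2-yl)sulfanyl gives a number 2 percentage points higher from compound 2 to compound 3 (within the scatter) in this assay, so this position accepts a five-membered aromatic ring in the tail with no movement beyond the scatter. Against the 2-methylprop-1-en-1-yl tail, ((1,3-thiazol-2-yl)sulfanyl)methyl gives a number 3 percentage points higher from compound 1 to compound 3 (within the scatter), leaving all three tails unseparated near the top of the scale. Nothing available bears on why they read alike.

As far as these compounds go, whether a tail ending in an amine or a carboxylic acid would hold this level remains open. So does whether these three tails would separate at a lower test concentration.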